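Ethyl to Isopropyl: A Single Methyl Step

The source may report more compounds than this note shows. Statements on the series, on what has been measured and on what is new or still open speak of the compounds shown alone.

Compound 1 `CCCCOC(=O)NS(=O)(=O)c1ccc(CCC)cc1-c1ccc(Cn2c(CC)nc3ccccc32)cc1` was tested in an assay on membranes from HEK293 cells for displacement of a labelled ligand from Type-2 angiotensin II receptor (Homo sapiens), read by radioligand binding (on this read-out higher numbers stand for weaker inhibition and lower numbers for stronger inhibition), and gives 11 nM. Two related compounds set the frame. Compound 2 `CCCc1ccc(S(=O)(=O)NC(=O)OCCCC(F)(F)F)c(-c2ccc(Cn3c(C(C)(C)C)nc4ccccc43)cc2)c1` gives 4.5 nM in this assay, and compound 3 `CCCCOC(=O)NS(=O)(=O)c1ccc(CCC)cc1-c1cc(F)c(Cn2c(C(C)(C)C)nc3ccccc32)c(F)c1` gives 11 nM. Compound 1 stands level with compound 3 at the digits shown, and these two together carry the highest numbers of the three, while compound 2 lies lower by an amount beyond the usual scatter. Compound 2 and compound 3 each differ from compound 1 in more than one place, so neither gap can be read as a single step.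

Compound 4 `CCCCOC(=O)NS(=O)(=O)c1ccc(CCC)cc1-c1ccc(Cn2c(C(C)C)nc3ccccc32)cc1` has not yet been measured. It differs from compound 1 in one place: methyl in place of hydrogen on a saturated chain carbon bound to an aromatic carbon and a saturated chain carbon. No single-step comparison exists to say what this change does here. Within the data shown here, the only hint is that compound 2 and compound 3, both carrying a larger group in place of the ethyl, give numbers that are lower than or level with that of compound 1.

On that basis a small step toward a lower number is expected, within or close to the scatter. Compound 4 is estimated to give 8 nM, with a range from 3 nM to 22 nM. The expected step is a 1.4-fold lower number from compound 1 to compound 4 (0.14 log units; within the scatter).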

Compound 4, inhibition constant: 4 nM
Compound 4: middle estimate off by 2.0-fold (0.30 log units), on the high side, and the stated range covers the measured number.
By their numbers in this assay, from the lowest: compounds 4 and 2 (each within the scatter of the next); then compounds 1 and 3 (each within the scatter of the next).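

Replacing ethyl with isopropyl gives a 2.8-fold lower number from compound 1 to compound 4 (0.44 log units; beyond the scatter) in this assay and so moves the number by more than the usual scatter, though the step is a modest one. Among these compounds, the earlier compounds could only hint at this, since compound 2 and compound 3 each differ from compound 1 in more than one place, whereas here a single methyl in place of hydrogen, on a saturated chain carbon bound to an aromatic carbon and a saturated chain carbon, is the only change. The compounds shown therefore establish that the number at this position responds to one added carbon, but no measurement is available to explain why it does.

A longer chain such as propyl, or a cyclopropyl group, in the same place on the core of compound 1 would show whether the number keeps moving in the same direction or whether the shape of the group matters more than its size. One step also leaves open whether this methyl would have a similar effect alongside the other differences carried by compound 2 and compound 3.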